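One more methoxy in a series at the limit

The compounds below may be only part of what the source reports. "The series", "measured", "known", "first", "only" and "open" are said of these compounds alone.

In an ADME assay on BJ cells (Homo sapiens) for cytotoxicity, read by luminescence, with a stated time of 72 h (a higher number here means that more compound is needed for the effect, a lower number that less compound is needed), the measured compounds stand as follows
- compound 1 `CCOC(=O)c1c(-c2cccc(C)c2)[nH]c2cc(OC)ccc2c1=O` gives > 21500 nM (a limit)
- compound 2 `CCOC(=O)c1c(-c2cccc(OCC(C)C)c2)[nH]c2cc(OC)ccc2c1=O` gives > 21500 nM (a limit)
- compound 3 `CCOC(=O)c1c(-c2cccc(Oc3ccccc3)c2)[nH]c2cc(OC)ccc2c1=O` gives > 21500 nM (a limit)

Compound 3 sits at > 21500 nM as a limit of the assay and not as a number. The two other compounds also give only limits, so no measured number places it within the series. The change to compound 4 `CCOC(=O)c1c(-c2cccc(Oc3ccccc3)c2)[nH]c2cc(OC)c(OC)cc2c1=O` is methoxy in place of hydrogen on an aromatic carbon on the shared core, with methoxy in place of hydrogen on an aromatic carbon, ortho to a methoxy group. The measured steps that bear on it are a step that the two limits leave unreadable from compound 1 to compound 3 and a step that the two limits leave unreadable from compound 2 to compound 3 and also a step that the two limits leave unreadable from compound 1 to compound 2 in the same series. None of them has a readable size, and none of them adds a methoxy. Resting on a step that the two limits leave unreadable from compound 2 to compound 3 and on the limit of > 21500 nM in this assay, at which 3 of the 3 values shown sit, in the series, no step beyond the usual scatter is expected in this assay for this change, and compound 4 is expected to return a limit as well. The expected change is a step that the limit leaves unreadable from compound 3 to compound 4 and remains a rough figure. For compound 4 the estimated value is 25000 nM with an expected range from 12000 nM to 50000 nM in this estimate.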

Compound 4, half-maximal effective concentration: > 21500 nM
Compound 4 ended at the assay's limit (the forecaster's own chance of this, stated with the estimate: 85%); the middle value lies beyond the limit too.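

In this assay compound 4 gives > 21500 nM, a limit of the assay and not a number. Among the compounds shown here, compound 3 also stands at a limit, so no step from compound 3 to compound 4 can be read. The compounds shown leave open how much of any of them is needed for the effect, and whether the changes among them alter it at all: the limit of > 21500 nM in this assay, at which 4 of the 4 values shown sit.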